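Replacing the oxetane on compound 1's piperazine nitrogen

The source may report more compounds than this note shows. Statements on the series, on what has been measured and on what is new or still open speak of the compounds shown alone.

Measured compounds:
- compound 1 `CN(C[C@H]1Cc2c(cccc2N2CCN(C3COC3)CC2)CN1)[C@H]1CCCc2cccnc21`: 381 nM
- compound 2 `C[C@@H]1CN(c2cccc3c2C[C@H](CN(C)[C@H]2CCCc4cccnc42)NC3)C[C@H](C)N1`: 61 nM
- compound 3 `CN(C[C@H]1Cc2c(cccc2N2CCN3CCC[C@H]3C2)CN1)[C@H]1CCCc2cccnc21`: 2.92 nM

Three compounds share one core and differ only in the group on an aromatic carbon. In a functional assay on CCRF-CEM cells for antagonist activity at C-X-C chemokine receptor type 4 (Homo sapiens), read by calcium flux, with stated times of 25 min and 90 s (a higher number here means a weaker inhibitor, a lower number a stronger inhibitor), compound 1 gives 381 nM, the highest of the three numbers, so it is the weakest inhibitor here: the steps of a 6.2-fold lower number from compound 1 to compound 2 (0.80 log units; beyond the scatter) and a 130-fold lower number from compound 1 to compound 3 (2.12 log units; beyond the scatter) both lie beyond the scatter.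

Compound 4 `CN(C[C@H]1Cc2c(cccc2N2CCN(Cc3ccccn3)CC2)CN1)[C@H]1CCCc2cccnc21` has not been measured. It differs from compound 1 in this way: (pyridin-2-yl)methyl in place of oxetan-3-yl on an amine nitrogen in a ring. For the measured compounds named here, no measured step makes exactly this change, so the step can only be read against the two that also alter what hangs off that aromatic carbon. Both of those lowered the number, one modestly and one by a large amount, and both removed the oxetan-3-yl from the piperazine nitrogen. The change to compound 4 also removes it, while keeping the piperazine ring itself. A lower number than compound 1 is therefore expected, probably of modest size, a 3.8-fold lower number from compound 1 to compound 4 (0.58 log units; beyond the scatter), with wide uncertainty. Compound 4 is estimated at 100 nM, within 25 nM to 500 nM.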

Compound 4, half-maximal inhibitory concentration: 4.47 nM
Compound 4: the middle estimate sits 22-fold (1.35 log units) above what was measured; the whole stated range lies above it.
By their numbers in this assay, from the lowest: compounds 3 and 4 (each within the scatter of the next); then compound 2; then compound 1.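

Putting (pyridin-2-yl)methyl in place of oxetan-3-yl on the amine nitrogen gives an 85-fold lower number from compound 1 to compound 4 (1.93 log units; beyond the scatter) in this assay. The earlier compounds shown here altered the piperazine itself as well as what it carries, whereas here the ring stays intact and only the group on that nitrogen changes, so this single swap is enough to bring compound 4 within the scatter of compound 3. Nothing measured here explains why this swap has so large an effect.

On these data alone, it remains open whether the nitrogen of the pyridine ring matters or any aromatic ring would serve, a question that a plain benzyl group on the same nitrogen could answer. As far as these compounds go, the effect of a longer chain between the piperazine nitrogen and the aromatic ring also remains open.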